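Chloro to amino on a purine core: a second look

A few compounds are considered here, and "the series" means these few. Any claim that something is new, unique, unknown or untested is made for them only; others in the source may bear on it.

Measured compounds:
Compound 1 `ClCc1ccccc1Cn1cnc2c(Cl)nc(Cl)nc21` in a functional assay on MCF7 cells (Homo sapiens) for cytotoxicity, read by sulforhodamine B assay, with a stated time of 48 h; a higher number here means a weaker inhibitor of growth, a lower number a stronger inhibitor of growth: compound 1 gives 1820 nM.
Compound 2 `ClCc1cccc(Cn2cnc3c(Cl)nc(Cl)nc32)c1`: compound 2 gives 6450 nM.
Compound 3 `Nc1nc(Cl)c2ncn(Cc3ccccc3CCl)c2n1`: compound 3 gives 24600 nM.

Compound 3 differs from compound 1 by one change, (amino in place of chloro on an aromatic carbon), and the step was a 14-fold higher number from compound 1 to compound 3 (1.13 log units; beyond the scatter). Compound 2 shares the atoms of compound 1 joined differently; how the two cores differ is not broken down here. Compound 4 `Nc1nc(Cl)c2ncn(Cc3cccc(CCl)c3)c2n1` carries the same change on the core of compound 2, (amino in place of chloro on an aromatic carbon), at a place described in the same words. Because the change from compound 1 to compound 3 gave a 14-fold higher number from compound 1 to compound 3 (1.13 log units; beyond the scatter), a step of similar size is expected, a 13-fold higher number from compound 2 to compound 4 (1.12 log units; beyond the scatter). Compound 4 is therefore estimated at 85000 nM, with a likely range from 30000 nM to 250000 nM.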

Compound 4, concentration for total growth inhibition: 9550 nM
Estimate against measurement, compound 4: 8.9-fold (0.95 log units) above; measured number below the stated range.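

In this assay the change from chloro to amino on the core of compound 2 gave a 1.5-fold higher number from compound 2 to compound 4 (0.17 log units; within the scatter), far from what the same change did on the core of compound 1. This shows that the size of this step depends on the core, so a step read on one core cannot simply be carried over to the other: the same change on two cores in this assay, a 14-fold higher number (1.13 log units; beyond the scatter) from compound 1 to compound 3 and a 1.5-fold higher number (0.17 log units; within the scatter) from compound 2 to compound 4, 9.1-fold (0.96 log units) apart, beyond the scatter of two such steps. It does not show why the two cores differ, and two pairs set no rule for other cores in this series.

The compounds shown leave open how a methylamino or methoxy group in place of chloro at this carbon would fare. From the compounds shown here alone, whether such steps would also depend on the core remains open too.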